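The source may report more compounds than this note shows. Statements on the series, on what has been measured and on what is new or still open speak of the compounds shown alone.

Going by the values given here, compound 2 `Cc1ccc(C(=O)Nc2cc3nc(C4CCCCC4)[nH]c3cc2Oc2ccc(F)cc2)cc1` is one of two compounds measured in an ADME assay on Vero cells (Chlorocebus sabaeus) for cytotoxicity, read by MTT assay, with a stated time of 2 days (a higher number here means a weaker inhibitor, a lower number a stronger inhibitor), where compound 2 gives 26000 nM. Among the compounds with values here, its only neighbour is compound 1 `COc1ccc(C(=O)Nc2cc3nc(C4CCCCC4)[nH]c3cc2Oc2ccc(F)cc2)cc1`, which in this assay gives 40000 nM; the two numbers sit within the usual scatter of each other, so no order between them can be read off. Within the data shown here, the single measured step, a 1.5-fold lower number from compound 1 to compound 2 (0.19 log units; within the scatter), swaps a methyl for a methoxy on the outer aromatic ring of the amide and moves the number by less than the scatter.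

Compound 3 `Cc1ccc(C(=O)Nc2cc3nc(C4CCCCC4)[nH]c3cc2Sc2ccccc2)cc1` keeps that methyl amide and changes the other side of the core: phenylsulfanyl in place of 4-fluorophenoxy on an aromatic carbon. Among the measured compounds shown here, no measured step touches this position, so the one known step bears on it only by showing that a small change elsewhere left the number essentially unchanged. On that thin basis no shift beyond the scatter is expected, and the step from compound 2 to compound 3 is estimated as no change at the digits printed from compound 2 to compound 3 (within the scatter). Compound 3 is therefore expected to give about 26000 nM in this assay, with a plausible range from 10000 nM to 65000 nM.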

Compound 3, half-maximal inhibitory concentration: 6250 nM
Estimate against measurement, compound 3: 4.2-fold (0.62 log units) above, and the stated range ends above it.
By their numbers in this assay, from the lowest: compound 3; then compounds 2 and 1 (each within the scatter of the next).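

Going by these compounds alone, this position matters in a way the earlier compounds could not show: in this assay, phenylsulfanyl in place of 4-fluorophenoxy gives a 4.2-fold lower number from compound 2 to compound 3 (0.62 log units; beyond the scatter). Within the data shown here, the only earlier step, on the outer ring of the amide, was a 1.5-fold lower number from compound 1 to compound 2 (0.19 log units; within the scatter), so of the two places changed so far, only the group on the aromatic carbon ortho to the ((4-methylphenyl)carbonyl)amino group has moved the number beyond the scatter. No outside measurement is available to explain this shift.

This single step makes two changes at once, replacing the linking oxygen with sulfur and removing the fluorine, and the compounds shown cannot separate them; phenoxy and 4-fluorophenylsulfanyl would each carry only one of the two changes. Also open, on these data alone, is whether an amine as the link to the ring, or a longer chain in that role, would take the number in this assay further in the same direction or back towards the value of compound 2, 26000 nM.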